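The source may hold more compounds than are shown below. What is called first, only, known or untested is meant among the compounds shown, and "the series" means these compounds.

Measured compounds:
compound 1 `Oc1cccc(-c2cc(-c3ccc(Cl)cc3)nc(-c3cccnc3)c2)c1` — 39500 nM
compound 2 `Oc1cccc(-c2cc(-c3cccc(Cl)c3)nc(-c3ccccn3)c2)c1` — "not determined" (no result reported)

In an ADME assay on HEK293 cells (Homo sapiens) for cytotoxicity, read by CCK-8 assay and cell counting, with a stated time of 2 days (on this read-out lower numbers stand for stronger inhibition and higher numbers for weaker inhibition), compound 1 gives 39500 nM. Compound 2 has no result in this assay, so compound 2 stands at no point on the numbers shown. Compound 3 `Oc1cccc(-c2cc(-c3ccc(Cl)cc3)nc(-c3ccccn3)c2)c1` differs from compound 2 by 4-chlorophenyl in place of 3-chlorophenyl on an aromatic carbon. Among the compounds with values here, no step between measured compounds is available to size this change, and compound 2 itself is unmeasured; the only number is that of compound 1. The expectation for compound 3 in this assay is therefore a shift no larger than the scatter, in no set direction. Compound 3 is estimated at 40000 nM, with a range from 15000 nM to 100000 nM.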

Compound 3, half-maximal inhibitory concentration: 14000 nM
Compound 3: middle estimate off by 2.9-fold (0.46 log units), on the high side; measured number below the stated range.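

In this assay, within the data shown here, pyridin-2-yl in place of pyridin-3-yl on an aromatic carbon, with 4-chlorophenyl kept, gives a 2.8-fold lower number from compound 1 to compound 3 (0.45 log units; beyond the scatter) and so provides the first sized change. The step from compound 2 to compound 3 cannot be read, which leaves the change from 3-chlorophenyl to 4-chlorophenyl unsized. Nothing available explains the shift with pyridin-2-yl.

On these data alone, whether the shift carries over to a 3-chlorophenyl compound remains open. Also open, as far as these compounds go, is how an amine or a carboxylic acid in place of the 3-hydroxyphenyl group would read here.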